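A few compounds are considered here, and "the series" means these few. Any claim that something is new, unique, unknown or untested is made for them only; others in the source may bear on it.

Compound 2 `O=C(NCc1ccc(CNS(=O)(=O)c2ccccc2)cc1)c1c(Cl)cc(Cl)cc1Cl` is, in an assay on MDA-MB-231 cells for binding affinity to C-X-C chemokine receptor type 4 (Homo sapiens), read by immunofluorescence and microscopy, with stated times of 10 min and 30 min (a higher number here means that more compound is needed for the effect, a lower number that less compound is needed), the lower of the two numbers recorded so far, giving 10 nM. Within the data shown here, its only neighbour is compound 1 `O=C(NCc1ccc(CNS(=O)(=O)c2ccccc2)cc1)c1ccccc1F`, which in this assay gives 1000 nM; the step of a 100-fold lower number from compound 1 to compound 2 (2.00 log units; beyond the scatter) is the one measured change, and it shows that the group on the carbonyl carbon can move the number a long way.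

Compound 3 `Cc1cccc(C(=O)NCc2ccc(CNS(=O)(=O)c3ccccc3)cc2)c1` has not been measured. Its difference from compound 2 is 3-methylphenyl in place of 2,4,6-trichlorophenyl on a carbonyl carbon. The step from compound 1 to compound 2 bears on this: replacing a small halogenated phenyl by 2,4,6-trichlorophenyl brought a large drop in the number, so taking the 2,4,6-trichlorophenyl away again, for 3-methylphenyl, is expected to go in the opposite direction. Compound 3 is therefore expected to give a higher number than compound 2 in this assay, with the step of a 50-fold higher number from compound 2 to compound 3 (1.70 log units; beyond the scatter) estimated to be large rather than within the scatter. The estimate for compound 3 is 500 nM, with a range from 100 nM to 3000 nM.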

Compound 3, effective concentration (reported as EC, without a stated level of effect): 1000 nM
For compound 3 the middle estimate is 2.0-fold (0.30 log units) below the measured one; measured number inside the range.
By their numbers in this assay, from the lowest: compound 2; then compounds 1 and 3 (each within the scatter of the next).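

In this assay, the change to 3-methylphenyl on the carbonyl carbon gives a 100-fold higher number from compound 2 to compound 3 (2.00 log units; beyond the scatter), so the low number of compound 2 is not kept when a different aromatic ring of carbon only takes the place of the 2,4,6-trichlorophenyl. The second step, no change at the digits printed from compound 1 to compound 3 (within the scatter), shows that 2-fluorophenyl and 3-methylphenyl cannot be told apart here, although one carries a halogen and the other a methyl group; among these three compounds, only the 2,4,6-trichlorophenyl group stands apart from the others. No accompanying measurement bears on why this group differs from the other two.

The compounds shown leave open whether the low number needs all three chlorine atoms or would also appear with a monochlorophenyl or dichlorophenyl group, and whether it depends on chlorine at all, which a comparison with 2,4,6-trimethylphenyl could address. They also leave open how this assay would respond to a group of another kind on the carbonyl carbon, such as a phenyl ring carrying a carboxylic acid or an amine.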